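The source may report more compounds than this note shows. Statements on the series, on what has been measured and on what is new or still open speak of the compounds shown alone.

Compound 3 `ClC(Cl)(Cl)c1nc(Oc2cccc(Br)c2)c2ccccc2n1` gives 36700 nM in an ADME assay on HepG2 cells (Homo sapiens) for cytotoxicity, read by MTT assay, with a stated time of 72 h; a lower number here means that less compound is tolerated, a higher number that more compound is tolerated. That figure stands lowest of the three numbers recorded so far, but both neighbours sit within the scatter of it: compound 1 `ClC(Cl)(Cl)c1nc(OCc2ccccc2)c2ccccc2n1` gives 43800 nM in this assay, and compound 2 `ClC(Cl)(Cl)c1nc(Oc2ccc(Br)cc2)c2ccccc2n1` gives 45000 nM. The three steps among them, a 1.0-fold higher number from compound 1 to compound 2 (0.01 log units; within the scatter), a 1.2-fold lower number from compound 1 to compound 3 (0.08 log units; within the scatter) and a 1.2-fold lower number from compound 2 to compound 3 (0.09 log units; within the scatter), all fall inside the scatter, so changing the group on the ether oxygen from benzyl to a bromophenyl, or moving the bromine on that phenyl, has so far left the half-maximal cytotoxic concentration essentially unmoved.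

Compound 4 `COc1cccc(Oc2nc(C(Cl)(Cl)Cl)nc3ccccc23)c1` is the next member of the set and differs from compound 3 in one place: methoxy in place of bromo on an aromatic carbon. Among the compounds with values here, no recorded step tests a methoxy against a bromo, so the expectation rests on the observation that every change on this aryl ether so far stayed within the scatter. A step from compound 3 to compound 4 of a 1.1-fold higher number from compound 3 to compound 4 (0.04 log units; within the scatter) is therefore expected, none beyond the scatter. Compound 4 is estimated to give 40000 nM in this assay, with a range from 20000 nM to 80000 nM.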

Compound 4, half-maximal cytotoxic concentration: 500 nM
The estimate for compound 4 lay 80-fold (1.90 log units) above the measured number; the whole stated range lies above it.
By their numbers in this assay, from the lowest: compound 4; then compounds 3, 1 and 2 (each within the scatter of the next).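

Within the data shown here, the change from bromo to methoxy gives a 73-fold lower number from compound 3 to compound 4 (1.87 log units; beyond the scatter) in this assay and is the first change on this aryl ether to go beyond the scatter. The earlier compounds shown here had suggested that this part of the molecule barely mattered, yet the group on this aromatic carbon, meta to a large group, can strongly alter how much compound the cells tolerate, even though changing benzyl to a bromophenyl or moving the bromine did not. Nothing measured here accounts for the size of this step.

The compounds shown leave open whether the drop is particular to methoxy or would also follow from a hydroxy, an ethoxy or an amine on the same carbon. They also leave open whether methoxy on another carbon of this ring would give a similar number.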